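Amide to urea on the anilide arm of the series

A few compounds are considered here, and "the series" means these few. Any claim that something is new, unique, unknown or untested is made for them only; others in the source may bear on it.

Measured so far:
compound 1 `COc1cc(-c2nn(-c3cccc(NC(=O)c4ccc(Cl)c(C(F)(F)F)c4)c3)cc2-c2ccncc2)ccc1Cl` — 660 nM
compound 2 `COc1cc(-c2nn(-c3cccc(NC(=O)c4cccc(C(F)(F)F)c4)c3)cc2-c2ccncc2)ccc1Cl` — 710 nM
compound 3 `O=C(Nc1cccc(-n2cc(-c3ccncc3)c(-c3ccc(Cl)c(O)c3)n2)c1)Nc1cc(C(F)(F)F)cc(C(F)(F)F)c1` — 910 nM

In a functional assay on MDA-MB-435 cells (Homo sapiens) for inhibition, read by sulforhodamine B assay, with a stated time of 48 h (on this read-out lower numbers stand for stronger inhibition and higher numbers for weaker inhibition), compound 2 gives 710 nM, the second highest of the three numbers. Its nearest neighbour is compound 1, which gives 660 nM, and the gap between them is within the scatter; the furthest is compound 3, which gives 910 nM, and that gap is also within the scatter. The three compounds thus stand together without any order that can be claimed.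

Compound 4 `COc1cc(-c2nn(-c3cccc(NC(=O)Nc4cccc(C(F)(F)F)c4)c3)cc2-c2ccncc2)ccc1Cl` is the next member. Against compound 2 the change is (3-(trifluoromethyl)phenyl)amino in place of 3-(trifluoromethyl)phenyl on a carbonyl carbon. Among the measured compounds shown here, the only single-point step measured so far is a 1.1-fold higher number from compound 1 to compound 2 (0.03 log units; within the scatter), which concerns a different part of the molecule and says nothing about the carbonyl carbon. Compound 3 carries the urea-type link that compound 4 acquires, but it differs from compound 2 in more than one place, so only its value can be set beside that of compound 2, and the two lie within the scatter of each other. For the measured compounds named here, no measured step therefore points to a change beyond the scatter. The step from compound 2 to compound 4 is expected to be a 1.2-fold higher number from compound 2 to compound 4 (0.08 log units; within the scatter). Compound 4 is expected to give 850 nM, within 400 nM to 1900 nM.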

Compound 4, half-maximal inhibitory concentration: 870 nM
Compound 4: middle estimate off by 1.0-fold (0.01 log units), on the low side, within the range that was stated.
By their numbers in this assay, from the lowest: compounds 1, 2, 4 and 3 (each within the scatter of the next).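

In this assay, the first step read at the carbonyl carbon, with (3-(trifluoromethyl)phenyl)amino in place of 3-(trifluoromethyl)phenyl, gives (a 1.2-fold higher number from compound 2 to compound 4 (0.09 log units; within the scatter)), so on this read-out the series tolerates the amide-to-urea change, with the entering group counting 1 hydrogen-bond donor against 0 for the group that leaves. The change at this position that also removes the chloro, with (3-(trifluoromethyl)phenyl)amino in place of 4-chloro-3-(trifluoromethyl)phenyl, likewise stays inside the scatter (a 1.3-fold higher number from compound 1 to compound 4 (0.12 log units; within the scatter)), so neither route into the urea separates it from the amides in this cell assay. Nothing at hand bears on why the urea and amide links read alike.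

The compounds shown carry only an aromatic ring on this carbonyl carbon, so it remains open whether a morpholine, a piperazine or a short alkyl amine there would keep the number in the same range. Among the compounds shown here, also open is whether a carbamate oxygen in place of the urea nitrogen, or a longer methylene chain ahead of the ring, would produce the first step at this position that lies beyond the scatter.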